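The source may hold more compounds than are shown below. What is called first, only, known or untested is meant among the compounds shown, and "the series" means these compounds.

Working notes on the series. Compound 1 `COc1ccc2[nH]c(C(=O)N3CC(=O)N(Cc4ccccc4)[C@@H](COCc4ccccc4)C3)cc2c1` carries a (benzyloxy)methyl group on a saturated ring carbon; in a physicochemical assay for solubility, read by spectrophotometry, in phosphate buffer, with a stated time of 2 h, at pH 7.4 (a lower number here means a less soluble compound, a higher number a more soluble compound), compound 1 gives 8800 nM. Compound 2 `COc1ccc2[nH]c(C(=O)N3CC(=O)N(Cc4ccccc4)[C@@H](N4[C@H](C)CCC[C@@H]4C)C3)cc2c1` has 2,6-dimethylpiperidin-1-yl at that position, and in this assay compound 2 gives 100000 nM, the change being an 11-fold higher number from compound 1 to compound 2 (1.06 log units; beyond the scatter). Compound 3 `COc1ccc2[nH]c(C(=O)N3CC(=O)N(Cc4ccccc4)[C@@H](CN4CC5CCCCC5C4)C3)cc2c1` gives 23800 nM in this assay, the second highest of the three numbers; it sits a 2.7-fold higher number from compound 1 to compound 3 (0.43 log units; beyond the scatter) and a 4.2-fold lower number from compound 2 to compound 3 (0.62 log units; beyond the scatter).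

Compound 4 `COc1ccc2[nH]c(C(=O)N3CC(=O)N(Cc4ccccc4)[C@@H](CN4CC5CCCC5C4)C3)cc2c1` is not yet measured in this assay. It differs from compound 3 by a group of 8 heavy atoms (7 carbon, 1 nitrogen; one five-membered non-aromatic ring of carbon only, one five-membered non-aromatic ring with 1 hetero atom) in place of a group of 9 heavy atoms (8 carbon, 1 nitrogen; one five-membered non-aromatic ring with 1 hetero atom, one six-membered non-aromatic ring of carbon only), on a saturated chain carbon bound to a saturated ring carbon. The measured steps that bear on this place are a 2.7-fold higher number from compound 1 to compound 3 (0.43 log units; beyond the scatter) and a 4.2-fold lower number from compound 2 to compound 3 (0.62 log units; beyond the scatter), both modest and both beyond the scatter, yet each exchanged groups of a different kind, whereas here the group leaving and the group entering are alike in kind and differ in a single ring. The step from compound 3 to compound 4 is therefore expected to be small, a 1.3-fold higher number from compound 3 to compound 4 (0.10 log units; within the scatter), and not beyond the scatter. Compound 4 is estimated at 30000 nM in this assay, with a range of 14000 nM to 65000 nM.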

Compound 4, solubility: 20700 nM
Beside the measured number, compound 4's estimate is 1.4-fold (0.16 log units) above it, and the stated range covers the measured number.
By their numbers in this assay, from the lowest: compound 1; then compounds 4 and 3 (each within the scatter of the next); then compound 2.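

In this assay, among the compounds shown here, replacing the six-membered carbon-only ring with a five-membered one, on a saturated chain carbon bound to a saturated ring carbon, gives a 1.1-fold lower number from compound 3 to compound 4 (0.06 log units; within the scatter); this is the first step that keeps the kind of group and alters a single ring, and it stays within the scatter. The other two steps, a 2.4-fold higher number from compound 1 to compound 4 (0.37 log units; beyond the scatter) and a 4.8-fold lower number from compound 2 to compound 4 (0.68 log units; beyond the scatter), run in the same directions as those to compound 3, so this ring change leaves compound 4 in the same position relative to compound 1 and compound 2. Nothing at hand explains these numbers.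

As far as these compounds go, whether a single-ring group such as morpholine or pyrrolidine on the same chain carbon would behave alike remains open. The compounds shown also cannot separate the group in compound 2 from its attachment on a saturated ring carbon, without the chain carbon.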